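Pyridin-3-yl in Place of Dimethoxyphenyl on the Core

The source may hold more compounds than are shown below. What is called first, only, known or untested is meant among the compounds shown, and "the series" means these compounds.

The measured compounds and their values:
compound 1, `CC(C(=O)NCc1ccc(C(F)(F)F)cc1OCc1ccccc1)c1ccc(NS(C)(=O)=O)c(F)c1`, 0.9 nM
compound 2, `CC(C(=O)NCc1ccc(C(F)(F)F)cc1F)c1ccc(NS(C)(=O)=O)c(F)c1`, 68.7 nM
compound 3, `COc1cc(OC)cc(-c2cc(C(F)(F)F)ccc2CNC(=O)C(C)c2ccc(NS(C)(=O)=O)c(F)c2)c1`, 5.8 nM

All three share one core and differ only in the group on one aromatic carbon. In an assay on CHO cells for antagonist activity at transient receptor potential cation channel subfamily V member 1 (Homo sapiens), read by FLIPR (a lower number here means a stronger inhibitor, a higher number a weaker inhibitor), compound 1 gives 0.9 nM. Compound 2, which carries fluoro there, gives 68.7 nM. Compound 3, with 3,5-dimethoxyphenyl, gives 5.8 nM and so stands between the other two: weaker than compound 1 (a 6.4-fold higher number from compound 1 to compound 3 (0.81 log units; beyond the scatter)) and stronger than compound 2 (a 12-fold lower number from compound 2 to compound 3 (1.07 log units; beyond the scatter)). The widest gap runs from compound 1 to compound 2 (a 76-fold higher number from compound 1 to compound 2 (1.88 log units; beyond the scatter)).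

Compound 4, `CC(C(=O)NCc1ccc(C(F)(F)F)cc1-c1cccnc1)c1ccc(NS(C)(=O)=O)c(F)c1`, has not yet been measured. It differs from compound 3 in one place: pyridin-3-yl in place of 3,5-dimethoxyphenyl on an aromatic carbon. The bearing steps show that a large aromatic group at this carbon, whether benzyloxy or 3,5-dimethoxyphenyl, goes with a far lower number than fluoro, while the exchange of one large group for another moved the number only modestly. Pyridin-3-yl keeps an aromatic ring at this carbon, so a step of modest size, if any beyond the scatter, is expected here, most likely toward a somewhat higher number than compound 3. Compound 4 is therefore estimated at 10 nM, within 3 nM to 40 nM, which would mean an expected step of a 1.7-fold higher number from compound 3 to compound 4 (0.24 log units; within the scatter).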

Compound 4, inhibition constant: 59.4 nM
Compound 4: middle estimate off by 5.9-fold (0.77 log units), on the low side, outside the stated range (above it).
By their numbers in this assay, from the lowest: compound 1; then compound 3; then compounds 4 and 2 (each within the scatter of the next).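

In this assay, the step from 3,5-dimethoxyphenyl to pyridin-3-yl is far from minor: a 10-fold higher number from compound 3 to compound 4 (1.01 log units; beyond the scatter) shows that an aromatic ring on this carbon does not by itself go with a low number. Set against fluoro, a 1.2-fold lower number from compound 2 to compound 4 (0.06 log units; within the scatter) leaves the two compounds indistinguishable, while a 66-fold higher number from compound 1 to compound 4 (1.82 log units; beyond the scatter) shows how far pyridin-3-yl stands from benzyloxy. The earlier contrast between fluoro and larger groups therefore holds for compounds 1 and 3, but compound 4 goes against it, so what matters at this carbon is more specific than the presence of a ring. Nothing shown offers an explanation for this step.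

The change removes the two methoxy groups and brings a ring nitrogen in the same step, so the compounds shown leave open which of these goes with the higher number, a question that an unsubstituted phenyl group on this carbon could help to separate. They also leave open whether pyridin-3-ylmethoxy would stay close to benzyloxy, or whether an amine or a carboxylic acid on the 3,5-dimethoxyphenyl ring would be tolerated.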